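Removing Two Oxygens From the Sulfur Substituent

The source may report more compounds than this note shows. Statements on the series, on what has been measured and on what is new or still open speak of the compounds shown alone.

Measured compounds:
Compound 1, `CSc1ccc(C)cc1NCC1=NCCN1`, gives 96%.
Compound 2, `CSc1ccc(F)cc1NCC1=NCCN1`, gives 92%.
Compound 3, `CS(=O)(=O)c1ccc(Cl)cc1NCC1=NCCN1`, gives 103%.

In a functional assay for agonist activity at Alpha-1B adrenergic receptor (Homo sapiens) (on this read-out lower numbers stand for smaller maximal responses and higher numbers for larger maximal responses), compound 3 has the highest of the three numbers; compound 1 lies within the scatter of it, and only the gap to compound 2 lies beyond the scatter. Compound 4, `CSc1ccc(Cl)cc1NCC1=NCCN1`, differs from compound 3 in one place: methylsulfanyl in place of methylsulfonyl on an aromatic carbon.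

Going by the values given here, no measured step changes this group, so none bears directly on it. Among the compounds with values here, the only measured step, a number 4 percentage points lower from compound 1 to compound 2 (within the scatter), changes a different place and is within the scatter. Compound 1 and compound 2 both carry methylsulfanyl; compound 1 gives 96% and compound 2 gives 92%, numbers that sit close to that of compound 3. The step of a number 8 percentage points lower from compound 3 to compound 4 (within the scatter) is therefore expected to stay within the scatter. Compound 4 is estimated to give 95%, within a range from 82% to 106%.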

Compound 4, largest response reached (reported as maximum), in percent of the reference or control that the assay uses: 103%
Compound 4: middle estimate off by 8 percentage points, on the low side; measured number inside the range.
By their numbers in this assay, from the lowest: compounds 2, 1, 3 and 4 (each within the scatter of the next, the first and the last beyond it).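

In this assay, methylsulfanyl in place of methylsulfonyl on this aromatic carbon gives no change at the digits printed from compound 3 to compound 4 (within the scatter) and so, with a chloro group in the para position, losing the two oxygens on the sulfur leaves the maximal response as it was. Compound 4 also shows how chloro compares with the other groups at that para position when methylsulfanyl is kept: chloro in place of fluoro gives a number 11 percentage points higher from compound 2 to compound 4 (beyond the scatter) and chloro in place of methyl gives a number 7 percentage points higher from compound 1 to compound 4 (within the scatter) so only the fluoro comparison lies beyond the scatter. Nothing measured here explains these results.

From the compounds shown here alone, whether methylsulfinyl, which has a single oxygen on the sulfur, or a longer chain such as ethylsulfanyl would give a similar response stays open. So does the effect of an amine on this aromatic carbon.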